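Benzoyl acrylates: swapping dichlorophenyl for nitrophenyl

The compounds below may be only part of what the source reports. "The series", "measured", "known", "first", "only" and "open" are said of these compounds alone.

Measured compounds:
compound 1 `O=C(OC/C(=C\c1ccccc1[N+](=O)[O-])C(=O)c1ccccc1)c1ccccc1` with 16000 nM
compound 2 `CC(=O)OC/C(=C/c1ccccc1[N+](=O)[O-])C(=O)c1ccccc1` with 52000 nM
compound 3 `O=C(OC/C(=C/c1ccc(Cl)cc1Cl)C(=O)c1ccccc1)c1ccccc1` with 5400 nM

All three were tested in a functional assay on T47D cells (Homo sapiens) for inhibition, read by sulforhodamine B assay, with a stated time of 48 h; on this read-out lower numbers stand for stronger inhibition of growth and higher numbers for weaker inhibition of growth. Compound 3 gives the lowest number of the three: compound 1 is the nearest, with a higher number that lies beyond the scatter, and compound 2 the furthest, with a still higher number, also beyond the scatter.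

The step to compound 4 `O=C(OC/C(=C/c1ccccc1[N+](=O)[O-])C(=O)c1ccccc1)c1ccccc1` consists of one change: 2-nitrophenyl in place of 2,4-dichlorophenyl on a double-bonded chain carbon bound to a double-bonded chain carbon. Going by the values given here, no measured pair shows this exact change, so the expectation rests on the neighbouring numbers. Compounds 1 and 2 both carry a 2-nitrophenyl group, and both give weaker inhibition of growth than compound 3, compound 1 with 16000 nM and compound 2 with 52000 nM. Compound 4 is therefore expected to lose some potency, with a step from compound 3 to compound 4 of about a 2.8-fold higher number from compound 3 to compound 4 (0.44 log units; beyond the scatter) in this assay. For compound 4 the estimate is 15000 nM, within a range of 5000 nM to 45000 nM.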

Compound 4, concentration for 50% growth inhibition: 18000 nM
For compound 4 the middle estimate is 1.2-fold (0.08 log units) below the measured one; low and high end bracket the measured number.
By their numbers in this assay, from the lowest: compound 3; then compounds 1 and 4 (each within the scatter of the next); then compound 2.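

In this assay, the direct step, a 3.3-fold higher number from compound 3 to compound 4 (0.52 log units; beyond the scatter), shows that 2-nitrophenyl in place of 2,4-dichlorophenyl on a double-bonded chain carbon bound to a double-bonded chain carbon costs potency when nothing else in the structure differs. With the 2-nitrophenyl group kept, phenyl in place of methyl on a carbonyl carbon gives a 2.9-fold lower number from compound 2 to compound 4 (0.46 log units; beyond the scatter), so that second place also affects the number. The remaining step, a 1.1-fold higher number from compound 1 to compound 4 (0.05 log units; within the scatter), does not separate the two drawn double-bond forms on this read-out, and this comparison isolates that single feature: the fact that compounds 1 and 4 differ only in the configuration as drawn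

The compounds shown leave open how a carboxylic acid or an amine would read in place of the nitro group. They also leave open whether a longer chain, such as propyl, in place of methyl on a carbonyl carbon would keep the number of compound 2 or shift it.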